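Fluoro in place of hydrogen on compound 3

The source may hold more compounds than are shown below. What is called first, only, known or untested is meant among the compounds shown, and "the series" means these compounds.

Measured compounds in this assay:
compound 1 `C[C@]1(CO)OC[C@@H](n2ccc(N)nc2=O)O1` — 45000 nM
compound 2 `C[C@]1(CO)OC[C@@H](n2cc(F)c(N)nc2=O)O1` — > 100000 nM
compound 3 `C[C@]1(CO)OCC(n2ccc(N)nc2=O)O1` — > 100000 nM

In a functional assay on L1210 cells (Mus musculus) for inhibition (on this read-out higher numbers stand for weaker inhibition and lower numbers for stronger inhibition), compound 1 gives 45000 nM. For compound 2 the value > 100000 nM is a limit of the assay, not a number. For compound 3 the value > 100000 nM is likewise a limit of the assay. Compound 3 therefore stands at the weak end of what is shown: of the three values, two sit at that limit, and compound 3 is one of them. Its step from compound 1, an at least 2.2-fold higher number from compound 1 to compound 3 (0.34 log units; beyond the scatter), rests on the change in how the stereocentre is drawn.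

Compound 4 `C[C@]1(CO)OCC(n2cc(F)c(N)nc2=O)O1` differs from compound 3 by fluoro in place of hydrogen on an aromatic carbon. Within the data shown here, the only measured step of this kind is an at least 2.2-fold higher number from compound 1 to compound 2 (0.34 log units; beyond the scatter), which took a numbered compound to the limit. Applied to compound 3, already at the limit, the same change is expected to leave a step that the limit leaves unreadable from compound 3 to compound 4, in the direction of weaker inhibition. Compound 4 is thus estimated at 300000 nM (range 100000 nM to 1000000 nM), and a limit rather than a number is the likely outcome because the limit of > 100000 nM in this assay, at which 2 of the 3 values shown sit, already holds compound 3.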

Compound 4, half-maximal inhibitory concentration: > 100000 nM
Compound 4 gave a limit, no number (the forecaster's own chance of this, stated with the estimate: 95%); the middle value does not contradict the limit.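

In this assay compound 4 gives > 100000 nM, a limit of the assay and not a number. No new step can be read: the steps from compound 3 and from compound 2 to compound 4 both end at limits. The compounds shown leave open whether the fluoro group or the drawn configuration changes inhibition once compounds sit at this limit.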